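Ester to acid step in a small fused-ring binding series

This account rests on a few compounds, and the source may have more. Where it says the series, first, only, none or still open, it means among the compounds named here.

Compound 1 `COC(=O)c1ccc2ccc(C=O)c-2cc1`: 25%
Compound 2 `O=Cc1ccc2ccc(C(=O)O)ccc1-2`: 37.8%
Compound 3 `COC(=O)Cc1ccc2ccc(C(=O)c3ccc(C(F)(F)F)cc3)c-2cc1`: -30.4%

In an assay on cells for displacement of a labelled ligand from Orexin/Hypocretin receptor type 1 (Homo sapiens), read by scintillation counting, with stated times of 10 min and 90 min, tested at 10 uM (a lower number here means less inhibition, a higher number more inhibition at the concentration tested (going by the name of the read-out)), compound 1 gives 25% and compound 2 gives 37.8%. The change between them, (hydrogen in place of methyl on an oxygen next to a carbonyl group), made a step of a number 12.8 percentage points higher from compound 1 to compound 2 (beyond the scatter). Compound 3 gives -30.4% in this assay, the lowest of the three numbers, and the difference between its core and the core of compound 1 is not broken down here.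

Compound 4 `O=C(O)Cc1ccc2ccc(C(=O)c3ccc(C(F)(F)F)cc3)c-2cc1` differs from compound 3 by hydrogen in place of methyl on an oxygen next to a carbonyl group; the place of the change reads the same as for the earlier pair, so it is the same change. Within the data shown here, the step from compound 3 to compound 4 is expected to be a number 15.4 percentage points higher from compound 3 to compound 4 (beyond the scatter), because a number 12.8 percentage points higher from compound 1 to compound 2 (beyond the scatter) is the only measured instance of this change and it was modest, though on a different core. For compound 4 the expected value in this assay is -15%, within -45% to 15%.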

Compound 4, a percentage reported as inhibition, at one concentration (the size of the read-out at that concentration, not a potency): 8.6%
For compound 4 the middle estimate is 23.6 percentage points below the measured one, within the range that was stated.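

In this assay, hydrogen in place of methyl on an oxygen next to a carbonyl group gives a step of a number 39 percentage points higher from compound 3 to compound 4 (beyond the scatter), so the direction of the change carries over to the second core but its size does not: the same change on two cores in this assay, a number 12.8 percentage points higher (beyond the scatter) from compound 1 to compound 2 and a number 39 percentage points higher (beyond the scatter) from compound 3 to compound 4, 26.2 percentage points apart, beyond the scatter of two such steps

On these two cores the carboxy compound reads higher than its methyl ester, but the size of the step on one core cannot be used to set its size on another. Two pairs do not show which feature of the cores goes with the larger step, and these are single-concentration inhibition read-outs, not potencies.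

Still open, on these data alone, is how an amide or a primary alcohol would read in place of the carboxy group. Also open, as far as these compounds go, is how a longer chain would compare with the carboxymethyl group of compound 4.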